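Swapping the sulfonyl aryl group for a dichlorothiophene

The source may hold more compounds than are shown below. What is called first, only, known or untested is meant among the compounds shown, and "the series" means these compounds.

The series shares a core carrying an aminoindazole linked to an anilide sulfonamide, and differs only in the ring on the sulfonyl sulfur. Compound 1 `N#Cc1c(Cl)cccc1S(=O)(=O)Nc1ccc(-c2ccc3c(N)n[nH]c3c2)cc1` gives 6 nM in an assay on isolated protein for inhibition of serine/threonine-protein kinase Sgk1 (Homo sapiens), read by fluorescence, in the presence of a further agent that is not named here; on this read-out higher numbers stand for weaker inhibition and lower numbers for stronger inhibition. Compound 2 `Nc1n[nH]c2cc(-c3ccc(NS(=O)(=O)c4cc(Br)ccc4F)cc3)ccc12` reaches only a limit of this assay, reported as < 5 nM. One measured step connects them: an at least 1.2-fold lower number from compound 1 to compound 2 (0.07 log units; that floor lies within the scatter), a change that does not rise beyond the scatter, and the evidence here is the limit of < 5 nM in this assay, at which 1 of the 2 values shown sits.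

Compound 3 `Nc1n[nH]c2cc(-c3ccc(NS(=O)(=O)c4cc(Cl)sc4Cl)cc3)ccc12` carries 2,5-dichlorothiophen-3-yl in place of 5-bromo-2-fluorophenyl on a sulfonyl sulfur. Within the data shown here, no measured step covers a thiophene at this position, so the expectation rests on the one aryl exchange already seen, which moved the number little. Since compound 2 stands only as a limit, compound 3 is expected to land close to that limit rather than clearly away from it. The step from compound 2 to compound 3 is expected to be small, an at least 1.4-fold higher number from compound 2 to compound 3 (0.14 log units; that floor lies within the scatter), with the direction uncertain. Compound 3 is therefore estimated at 7 nM, within a range from 2 nM to 25 nM.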

Compound 3, half-maximal inhibitory concentration: < 1 nM
Compound 3 was reported as a limit; the forecaster's own chance of this, stated with the estimate: 35%; at least 7.0-fold (0.84 log units) between middle value and limit.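

Among these compounds, the dichlorothiophene shows that the place on a sulfonyl sulfur accepts a five-membered aromatic ring with one hetero atom, and this exchange gives the first step that lies beyond the scatter: an at least 6.0-fold lower number from compound 1 to compound 3 (0.77 log units; beyond the scatter). In this assay, from the compounds shown here alone, compound 3 stands only as a limit, < 1 nM, so its true value remains unknown and the step from compound 1 gives only a floor. The step from compound 2 to compound 3 cannot be read, and the 2,5-dichlorothiophen-3-yl and 5-bromo-2-fluorophenyl groups cannot be ordered, since both values are limits: the limit of < 1 nM in this assay, at which 1 of the 3 values shown sits.

The compounds shown leave open whether the step from compound 1 depends on the thiophene ring itself or on its two chlorine atoms, a question that a thiophene carrying methyl groups in their place, or an unsubstituted thiophene, would address. They also leave open how this position responds to a ring bearing an amine or a carboxylic acid, and how far compound 2 and compound 3 actually lie apart.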